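Working notes: from compound 3 to compound 4

The compounds below may be only part of what the source reports. "The series", "measured", "known", "first", "only" and "open" are said of these compounds alone.

Measured in a functional assay on HCT-116 cells (Homo sapiens) for inhibition, with a stated time of 72 h; on this read-out lower numbers stand for stronger inhibition and higher numbers for weaker inhibition:
compound 1 `NC1CCC(Nc2nc(NCc3ccc(-c4cccc(F)c4)cc3)c3ncn(C4CCCC4)c3n2)CC1`: 551 nM
compound 2 `NC1CCC(Nc2nc(NCc3ccc(-c4ccco4)cc3)c3ncn(C4CCCC4)c3n2)CC1`: 129 nM
compound 3 `NC1CCC(Nc2nc(NCc3ccc(-n4cccn4)cc3)c3ncn(C4CCCC4)c3n2)CC1`: 320 nM

Two measured steps reach compound 3. One stays within the scatter: a 1.7-fold lower number from compound 1 to compound 3 (0.24 log units; within the scatter). The other goes beyond it: a 2.5-fold higher number from compound 2 to compound 3 (0.39 log units; beyond the scatter). Compound 3 therefore stands level with one neighbour and clear of the other.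

The next structure is compound 4 `NC1CCC(Nc2nc(NCc3cc(Cl)ccc3O)c3ncn(C4CCCC4)c3n2)CC1`, which carries 5-chloro-2-hydroxyphenyl in place of 4-(1H-pyrazol-1-yl)phenyl on a saturated chain carbon bound to a nitrogen on an aromatic ring. The shared core stays the same.

The measured steps bear on this change only in part. All three exchange only the outer group on an aromatic carbon, and the largest is a 4.3-fold lower number from compound 1 to compound 2 (0.63 log units; beyond the scatter). None of them removes that outer ring or tests a chloro or hydroxy group, so they give no direction for compound 4. Within the data shown here, they show only that changes in this region have moved this assay modestly. No step beyond the scatter is expected, though with low confidence.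

For compound 4 the expected step is a 1.3-fold lower number from compound 3 to compound 4 (0.11 log units; within the scatter). For compound 4 the estimated value is 250 nM, with an expected range from 60 nM to 1000 nM.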

Compound 4, half-maximal inhibitory concentration: 350 nM
For compound 4 the middle estimate is 1.4-fold (0.15 log units) below the measured one; measured number inside the range.
By their numbers in this assay, from the lowest: compound 2; then compounds 3, 4 and 1 (each within the scatter of the next).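

The result shows that the place on a saturated chain carbon bound to a nitrogen on an aromatic ring does not depend on the two-ring 4-aryl type of group in this assay: 5-chloro-2-hydroxyphenyl, with one six-membered aromatic ring of carbon only, stands level with 4-(1H-pyrazol-1-yl)phenyl (a 1.1-fold higher number from compound 3 to compound 4 (0.04 log units; within the scatter)). The same group does not match 4-(furan-2-yl)phenyl (a 2.7-fold higher number from compound 2 to compound 4 (0.43 log units; beyond the scatter)), so the furan-2-yl compound keeps its lead over compound 4, as it did over compound 3, even though the group entering here is of a different type from those compared earlier. No evidence is available to explain either step.

Compound 4 alters the ring count, the chlorine and the hydroxy group in one move, so the compounds shown cannot assign the level result to any one of these, and the contribution of each remains unknown. Still open, going by these compounds, is how this place responds to a plain 2-hydroxyphenyl without chlorine, or to a methoxy group, an amine or a carboxylic acid where the hydroxy group stands in compound 4.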